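This account rests on a few compounds, and the source may have more. Where it says the series, first, only, none or still open, it means among the compounds named here.

Measured so far in a functional assay on MCF7 cells (Homo sapiens) for antiproliferative activity, read by MTT assay, with a stated time of 72 h; on this read-out lower numbers stand for stronger inhibition and higher numbers for weaker inhibition:
- compound 1 `CCN(CC)CCCNC(=O)c1ccc(C(CC)(CC)c2ccc(C#CC(O)(CC)CC)c(C)c2)n1CC`: 17800 nM
- compound 2 `CCn1c(C(=O)NCC(=O)O)ccc1C(CC)(CC)c1ccc(C#CC(O)(CC)CC)c(C)c1`: 5140 nM
- compound 3 `CCn1cc(C(CC)(CC)c2ccc(C#CC(O)(CC)CC)c(C)c2)cc1C(=O)NCC(=O)OC`: 26500 nM

Compound 3, at 26500 nM, lies within the scatter of compound 1 and clearly above compound 2, which gives 5140 nM. Compound 4 `CCn1cc(C(CC)(CC)c2ccc(C#CC(O)(CC)CC)c(C)c2)cc1C(=O)NCC(=O)O` differs from compound 3 in one place: hydrogen in place of methyl on an oxygen next to a carbonyl group. Methoxycarbonyl thus becomes carboxy. Going by the values given here, no measured pair makes this exact change. The nearest evidence is the modest step of a 3.5-fold lower number from compound 1 to compound 2 (0.54 log units; beyond the scatter), where a carboxy end replaced 2-(diethylamino)ethyl, and compound 4 carries that same carboxy end. A modest fall in this assay is therefore expected, estimated as a 2.2-fold lower number from compound 3 to compound 4 (0.34 log units; beyond the scatter), though the evidence is indirect. The estimated value for compound 4 is 12000 nM, with an expected range from 4500 nM to 32000 nM.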

Compound 4, half-maximal inhibitory concentration: 17500 nM
Compound 4: the middle estimate sits 1.5-fold (0.16 log units) below what was measured; low and high end bracket the measured number.
By their numbers in this assay, from the lowest: compound 2; then compounds 4, 1 and 3 (each within the scatter of the next).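

In this assay, hydrogen in place of methyl on this oxygen next to a carbonyl group gives a 1.5-fold lower number from compound 3 to compound 4 (0.18 log units; within the scatter), so turning methoxycarbonyl into carboxy here has no effect that can be told from the scatter. Going by these compounds alone, this pair is the first direct reading of that change, and in it a carboxy end brings no clear shift. Nothing measured here says why this is so. Still open, going by these compounds, is whether a longer chain on this oxygen, or an amine in its place, would move the number beyond the scatter. Also open, on these data alone, is whether the same change would behave alike on the core of compound 2.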